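The compounds below may be only part of what the source reports. "The series", "measured", "known", "first", "only" and "open" are said of these compounds alone.

Measured in a functional assay on HeLa cells (Homo sapiens) for cytotoxicity, read by MTT assay; on this read-out higher numbers stand for weaker inhibition and lower numbers for stronger inhibition:
- compound 1 `CC(C)=CC[C@@H](OC(=O)CCO)C1=CC(=O)c2c(O)ccc(O)c2C1=O`: 67600 nM
- compound 2 `CC(=O)OCCC(=O)O[C@H](CC=C(C)C)C1=CC(=O)c2c(O)ccc(O)c2C1=O`: 17300 nM

Compound 2 holds the lower of these two numbers. Its neighbour compound 3 `CCCCC(O)CC(=O)O[C@H](CC=C(C)C)C1=CC(=O)c2c(O)ccc(O)c2C1=O` differs from it by 1-hydroxypentyl in place of acetoxymethyl on a saturated chain carbon bound to a carbonyl carbon, with 1-hydroxypentyl in place of acetoxymethyl on a saturated chain carbon bound to a carbonyl carbon. Among the measured compounds shown here, only one measured step bears on this change: a 3.9-fold lower number from compound 1 to compound 2 (0.59 log units; beyond the scatter), modest but beyond the scatter, with acetyl in place of hydrogen on an oxygen on a saturated carbon. Compound 3 has no acetyl and carries a hydroxy group, as does compound 1 at 67600 nM, so part of that step may reverse. For the measured compounds named here, its longer chain has no measured precedent. A shift towards a higher number is therefore expected in this assay, smaller than the measured step and possibly within the scatter. The expected change is a 1.4-fold higher number from compound 2 to compound 3 (0.16 log units; within the scatter). For compound 3 the estimate is 25000 nM, with an expected range of 8000 nM to 70000 nM.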

Compound 3, half-maximal inhibitory concentration: 72200 nM
Beside the measured number, compound 3's estimate is 2.9-fold (0.46 log units) below it; measured number above the stated range.
By their numbers in this assay, from the lowest: compound 2; then compounds 1 and 3 (each within the scatter of the next).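

In this assay, the swap of acetoxymethyl for 1-hydroxypentyl on a saturated chain carbon bound to a carbonyl carbon gives a 4.2-fold higher number from compound 2 to compound 3 (0.62 log units; beyond the scatter), so this change does not leave the number of compound 2 in place. Butyl in place of hydrogen on the chain gives a 1.1-fold higher number from compound 1 to compound 3 (0.03 log units; within the scatter), so at this position the added butyl has no effect beyond the scatter while the hydroxy group stays free, and among these three compounds only the acetylated compound 2 stands apart. Nothing given here explains these differences.

On these data alone, it remains open whether acetyl on the hydroxy group of compound 3 would lower its number as it does from compound 1 to compound 2. As far as these compounds go, how an amine or a carboxylic acid in place of that hydroxy group would read in this assay also stays unknown.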